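A few compounds are considered here, and "the series" means these few. Any claim that something is new, unique, unknown or untested is made for them only; others in the source may bear on it.

Working notes on the series. In an assay on membranes from liver for displacement of a labelled ligand from Sigma intracellular receptor 2 (Rattus norvegicus), read by scintillation counting, with a stated time of 120 min, in the presence of a further agent that is not named here (a higher number here means a weaker inhibitor, a lower number a stronger inhibitor), compound 1 `O=C1CCc2ccccc2N1CCCCN1CCN(C2CCCCC2)CC1` gives 1.5 nM, and in this assay compound 2 `O=C1CCc2ccccc2N1CCCCN1CCN(c2ccc(F)cc2)CC1` gives 21 nM. For the measured compounds named here, compound 2 thus holds the highest of the two numbers measured so far, with compound 1 as its only neighbour; the one measured step is a 14-fold higher number from compound 1 to compound 2 (1.15 log units; beyond the scatter). Compound 3 `O=C1CCc2ccccc2N1CCCCN1CCN(c2ccccn2)CC1` is the next member: pyridin-2-yl in place of 4-fluorophenyl on an amine nitrogen in a ring. Going by the values given here, no measured step swaps one aromatic group for another; the only step available, a 14-fold higher number from compound 1 to compound 2 (1.15 log units; beyond the scatter), concerns the exchange of cyclohexyl for an aromatic group and so bears on this change only indirectly. The replacement of one six-membered aromatic ring by another is expected to move the number less than that step did, and an essentially flat outcome is expected, a 1.4-fold higher number from compound 2 to compound 3 (0.15 log units; within the scatter). Compound 3 is therefore estimated at 30 nM in this assay, with a range from 8 nM to 110 nM.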

Compound 3, inhibition constant: 73 nM
Compound 3: middle estimate off by 2.4-fold (0.39 log units), on the low side; the range from low to high includes it.
By their numbers in this assay, from the lowest: compound 1; then compound 2; then compound 3.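

In this assay, the exchange of one six-membered aromatic ring for another on this amine nitrogen in a ring is not neutral: there is a 3.5-fold higher number from compound 2 to compound 3 (0.54 log units; beyond the scatter), so the identity of the aromatic group matters here, and not only the choice between cyclohexyl and an aromatic group. Measured against cyclohexyl, pyridin-2-yl gives a 49-fold higher number from compound 1 to compound 3 (1.69 log units; beyond the scatter), which exceeds a 14-fold higher number from compound 1 to compound 2 (1.15 log units; beyond the scatter) and places both aromatic groups on the higher-number side of cyclohexyl, with pyridin-2-yl the higher of the two. No available data account for the difference between these two aromatic groups.

The step removes the fluorine and introduces the ring nitrogen at once, and plain phenyl would be needed to separate the two changes. On these data alone, whether other saturated groups, such as cyclopentyl or piperidin-4-yl, keep the low number of compound 1 remains open.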